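The source may hold more compounds than are shown below. What is called first, only, known or untested is meant among the compounds shown, and "the series" means these compounds.

Among the compounds with values here, in a functional assay on B16-F10 cells (Mus musculus) for antiproliferative activity, read by colorimetric assay and MTT assay, with a stated time of 48 h (on this read-out higher numbers stand for weaker inhibition and lower numbers for stronger inhibition), three compounds have numbers so far. Compound 1 `O=C(NS(=O)(=O)c1ccccc1)c1cncc(C(=O)NS(=O)(=O)c2ccccc2)c1` gives 11300 nM and compound 2 `O=C(NS(=O)(=O)c1ccc(Cl)cc1)c1cncc(C(=O)NS(=O)(=O)c2ccc(Cl)cc2)c1` gives 10600 nM while compound 3 `O=C(NS(=O)(=O)c1ccc(F)cc1)c1ccncc1` gives 13800 nM on the same read-out. These three numbers lie within the usual scatter of repeated measurements, so compound 3 stands level with the other two and no ranking among them can be drawn.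

The next compound is compound 4 `O=C(NS(=O)(=O)c1ccc(Cl)cc1)c1ccncc1`. It differs from compound 3 in one place, with chloro in place of fluoro on an aromatic carbon. That carbon belongs to a six-membered aromatic ring of carbon only and lies para to a large group. Within the data shown here, no measured pair isolates a single change, so the data give no direct size for this swap. Compound 2 also carries chloro, and its 10600 nM lies within the scatter of compound 3 at 13800 nM on this read-out. In this assay the estimated step (a 1.2-fold lower number from compound 3 to compound 4 (0.06 log units; within the scatter)) is therefore expected to stay inside the scatter, with no clear direction. For compound 4 the estimated value is 12000 nM (expected range 7000 nM to 20000 nM).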

Compound 4, half-maximal inhibitory concentration: 12400 nM
Estimate against measurement, compound 4: 1.0-fold (0.01 log units) below; the measured number falls inside the stated range.
By their numbers in this assay, from the lowest: compounds 2, 1, 4 and 3 (each within the scatter of the next).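

Within the data shown here, this is the first pair here that differs in one place, so a single change can now be sized directly. In this assay, putting chloro in place of fluoro on an aromatic carbon, para to a large group, gives a small step (a 1.1-fold lower number from compound 3 to compound 4 (0.05 log units; within the scatter)). Compound 3 and compound 4 therefore stand level, and at this position the swap leaves no readable mark on the number; no measurement at hand bears on why.

The compounds shown carry only fluoro and chloro at this position, so it remains open whether an amine, a methoxy group or a carboxylic acid there would shift the number beyond the scatter. From the compounds shown here alone, whether the same swap behaves alike on the core of compound 1 also remains open.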